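Sulfonyl aryl exchange on compound 3: clearance outlook

The source may hold more compounds than are shown below. What is called first, only, known or untested is meant among the compounds shown, and "the series" means these compounds.

The series shares the core seen in compound 1 `CCn1c([C@@H](C)NS(=O)(=O)c2ccc(Cl)cc2)nc2ccc(OC)cc21`, compound 2 `CCn1c([C@@H](C)NS(=O)(=O)c2ccc(Cl)cc2)nc2cc(CO)ccc21` and compound 3 `CCn1c([C@@H](C)NS(=O)(=O)c2ccc(C)cc2)nc2ccc(C(F)(F)F)cc21`; the three differ in the substituent on the fused ring system and in the aryl group on the sulfonyl sulfur. Compound 3 has been run in an ADME assay (liver) for metabolic stability, with Liver microsome (Homo sapiens) as the target, read by LC-MS, using microsomes and NADPH, with a stated time of 5 min, at 37 degrees C; on this read-out lower numbers stand for slow clearance and higher numbers for fast clearance. In this assay compound 3 reaches only a limit, > 100 mL.min-1.g-1, not a number. Compound 1 likewise sits at a limit in this assay, > 100 mL.min-1.g-1. Compound 2 gives 88 mL.min-1.g-1 in this assay, a measured number rather than a limit. Two of the three values shown thus sit at the limit of > 100 mL.min-1.g-1 in this assay, at which 2 of the 3 values shown sit, and compound 3 stands at the upper edge of what this assay reports.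

Compound 4 `CCn1c([C@@H](C)NS(=O)(=O)c2cnn(C(C)C)c2C)nc2ccc(C(F)(F)F)cc21` differs from compound 3 in a single place: 1-isopropyl-5-methyl-1H-pyrazol-4-yl in place of 4-methylphenyl on a sulfonyl sulfur. Among the compounds with values here, no pair of measured compounds here differs in one place only, so there is no measured step to set the size of the effect. The step from compound 3 to compound 4 is expected to be a fall in this assay, of an at least 1.8-fold lower number from compound 3 to compound 4 (0.25 log units; that floor lies within the scatter), large enough to bring the read-out off the limit. Compound 4 is therefore expected to give about 55 mL.min-1.g-1 in this assay, within a range of 25 mL.min-1.g-1 to 100 mL.min-1.g-1.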

Compound 4, intrinsic clearance in microsomes: > 100 mL.min-1.g-1
Compound 4 gave a limit, no number; the forecaster's own chance of this, stated with the estimate: 35%; middle value at least 1.8-fold (0.25 log units) from the limit.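

In this assay compound 4 gives > 100 mL.min-1.g-1 as a limit and not a number. Within the data shown here, compound 3 also stands at a limit, so no step from compound 3 to compound 4 can be read, and the values shown remain crowded at the top of the read-out: the limit of > 100 mL.min-1.g-1 in this assay, at which 3 of the 4 values shown sit. From the compounds shown here alone, whether 1-isopropyl-5-methyl-1H-pyrazol-4-yl in place of 4-methylphenyl on a sulfonyl sulfur changes clearance at all, and in which direction, stays open.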